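Phenyl in place of benzyl on compound 1

A few compounds are considered here, and "the series" means these few. Any claim that something is new, unique, unknown or untested is made for them only; others in the source may bear on it.

In a functional assay on the whole organism with Mus musculus as the target (a lower number here means that less compound is needed, a higher number that more compound is needed for the effect), compound 1 `C[C@@H](NCc1ccc(OCc2ccccc2)cc1)C(N)=O` gives 23.8 mg/kg, the middle of three numbers. Compound 2 `CNC(=O)[C@H](C)NCc1ccc(OCc2ccccc2)cc1` gives the lowest, 8.4 mg/kg, and compound 3 `CC[C@H](NCc1ccc(OCc2ccccc2)cc1)C(N)=O` the highest, 119 mg/kg.

The next structure, compound 4 `C[C@@H](NCc1ccc(Oc2ccccc2)cc1)C(N)=O`, keeps the amide side of compound 1 and changes the other end: phenyl in place of benzyl on an oxygen on an aromatic ring. This is phenyl in place of benzyl on an oxygen on an aromatic ring.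

Among the compounds with values here, no measured step touches that place, as all three lie on the amine nitrogen: a 2.8-fold lower number from compound 1 to compound 2 (0.45 log units; beyond the scatter), a 5.0-fold higher number from compound 1 to compound 3 (0.70 log units; beyond the scatter) and a 14-fold higher number from compound 2 to compound 3 (1.15 log units; beyond the scatter). These steps show that this assay can move well beyond the scatter with single changes in this series, but they give no direct guide to direction here. A modest step towards a higher number is expected, and the direction remains uncertain.

The estimated step is a 1.7-fold higher number from compound 1 to compound 4 (0.23 log units; within the scatter).

For compound 4 the expected value is 40 mg/kg, with an estimated range from 12 mg/kg to 130 mg/kg.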

Compound 4, dose for half-maximal effect: 64 mg/kg
The estimate for compound 4 lay 1.6-fold (0.20 log units) below the measured number; low and high end bracket the measured number.
By their numbers in this assay, from the lowest: compound 2; then compound 1; then compounds 4 and 3 (each within the scatter of the next).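

The oxygen end of the molecule also matters: in this assay, phenyl in place of benzyl on an oxygen on an aromatic ring gives a 2.7-fold higher number from compound 1 to compound 4 (0.43 log units; beyond the scatter) and so moves the number beyond the scatter, as the changes on the amine nitrogen did. The two groups differ only in heavy-atom count, while the aromatic ring, hydrogen-bond donors, hydrogen-bond acceptors and charge stay the same. No measurement at hand accounts for the step.

On these data alone, with only benzyl and phenyl to compare on this oxygen, it remains open whether a 2-phenylethyl group would give a lower number than benzyl or continue the trend in some other way. Also open, as far as these compounds go, is whether the step from benzyl to phenyl keeps its direction and size when the 1-(methylcarbamoyl)ethyl or 1-carbamoylpropyl group sits on the amine nitrogen.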